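An Isopropyl Group Added to a Fused Core

The source may report more compounds than this note shows. Statements on the series, on what has been measured and on what is new or still open speak of the compounds shown alone.

Going by the values given here, compound 1 `O=c1c2c(C(F)(F)F)cc(-c3ccccc3)nc2ncn1Cc1cn(CCC(F)(F)C(F)(F)C(F)(F)C(F)(F)C(F)(F)C(F)(F)C(F)(F)C(F)(F)F)nn1` is the only compound in this set with a number in a functional assay on COLO 205 cells (Homo sapiens) for cytotoxicity, read by MTT assay, with a stated time of 24 h; a lower number here means a stronger inhibitor, a higher number a weaker inhibitor: compound 1 gives 163 ug/mL. Compound 2 `CCCCCCCCCCn1cc(Cn2c(CC)nc3nc(-c4ccccc4)cc(C(F)(F)F)c3c2=O)nn1` reaches only the assay limit there; in this assay compound 2 gives > 200 ug/mL, which is a limit and not a number (the limit of > 200 ug/mL in this assay, at which 1 of the 2 values shown sits). Compound 3 `CC(C)c1nc2nc(-c3ccccc3)cc(C(F)(F)F)c2c(=O)n1Cc1cn(CCC(F)(F)C(F)(F)C(F)(F)C(F)(F)C(F)(F)C(F)(F)C(F)(F)C(F)(F)F)nn1` differs from compound 1 by isopropyl in place of hydrogen on an aromatic carbon. Among the compounds with values here, no pair of measured compounds shows the effect of such a step, so the expected step is no larger than the usual scatter, estimated as a 1.2-fold higher number from compound 1 to compound 3 (0.07 log units; within the scatter), with some chance that compound 3 is again expected to reach only a limit. Compound 3 is therefore expected to give 190 ug/mL, between 110 ug/mL and 320 ug/mL.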

Compound 3, half-maximal inhibitory concentration: > 200 ug/mL
Compound 3: only a limit was reported (the forecaster's own chance of this, stated with the estimate: 50%); middle value at least 1.0-fold (0.02 log units) away from the limit.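

With isopropyl in place of hydrogen on the aromatic carbon between two ring nitrogen atoms, in this assay compound 3 gives > 200 ug/mL, which is a limit and not a number. As far as these compounds go, the change therefore gives only a floor, an at least 1.2-fold higher number from compound 1 to compound 3 (0.08 log units; that floor lies within the scatter), and the true size of the step stays unknown. This is the second limit in the set: the limit of > 200 ug/mL in this assay, at which 2 of the 3 values shown sit.

From the compounds shown here alone, whether a methyl group or an amine at this position would give a number below that limit stays open. Going by these compounds, the effect of isopropyl on any other core also stays open.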